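A few compounds are considered here, and "the series" means these few. Any claim that something is new, unique, unknown or untested is made for them only; others in the source may bear on it.

The measured compounds in an assay on membranes from Sf9 cells for displacement of a labelled ligand from histamine H2 receptor (Homo sapiens), read by scintillation counting, with a stated time of 60 min; a higher number here means a weaker inhibitor, a lower number a stronger inhibitor:
compound 1, `Cc1nc(N)sc1CCCN/C(N)=N/C(=O)NCC(C)CCc1ccccc1`, gives 63.1 nM;
compound 2, `CCCNC(=O)/N=C(\N)NCCCc1sc(N)nc1C`, gives 105 nM;
compound 3, `CCC(NC(=O)/N=C(\N)NCCCc1sc(N)nc1C)c1ccccc1`, gives 63.1 nM.

Compound 2 has the highest number of the three, yet both of its neighbours lie within the scatter of it: a 1.7-fold higher number from compound 1 to compound 2 (0.22 log units; within the scatter) and a 1.7-fold lower number from compound 2 to compound 3 (0.22 log units; within the scatter). On these numbers, then, nothing separates the three compounds.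

The unmeasured compound 4, `Cc1nc(N)sc1CCCN/C(N)=N/C(=O)NC(C)c1cccs1`, differs from compound 2 in one place: 1-(thiophen-2-yl)ethyl in place of propyl on an amide-type nitrogen. Among the measured compounds shown here, two measured steps bear on it, both of which alter the substituent on the same side of the urea. The step of a 1.7-fold higher number from compound 1 to compound 2 (0.22 log units; within the scatter) removes an aromatic group from the chain; the step of a 1.7-fold lower number from compound 2 to compound 3 (0.22 log units; within the scatter) adds one on the carbon bound to the amide-type nitrogen. Each is small and within the scatter. The change to compound 4 again places an aromatic ring on this carbon, so the expected step of a 1.8-fold lower number from compound 2 to compound 4 (0.24 log units; within the scatter) is in the direction of a lower number, with no confidence that it exceeds the scatter. Compound 4 is therefore estimated at 60 nM, within 25 nM to 150 nM.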

Compound 4, inhibition constant: 63.1 nM
Compound 4: the middle estimate sits 1.1-fold (0.02 log units) below what was measured; the measured number falls inside the stated range.
By their numbers in this assay, from the lowest: compounds 1, 3, 4 and 2 (each within the scatter of the next).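

In this assay, putting 1-(thiophen-2-yl)ethyl in place of propyl on the amide-type nitrogen gives a 1.7-fold lower number from compound 2 to compound 4 (0.22 log units; within the scatter). The earlier steps shown here at this side of the urea involved only all-carbon groups, whereas this one shows that a group with a sulfur atom, a five-membered aromatic ring with 1 hetero atom and 1 hydrogen-bond acceptor also leaves the number within the scatter. No measured evidence accounts for this result or isolates what the sulfur atom contributes.

All the steps shown stay within the scatter, so the compounds leave open whether any change on this nitrogen can separate one compound from another. As far as these compounds go, whether an amine, a carboxylic acid or a longer chain in this place would give a step beyond the scatter also remains unknown.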